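The source may report more compounds than this note shows. Statements on the series, on what has been measured and on what is new or still open speak of the compounds shown alone.

Working notes on the step from compound 1 `C#Cc1cn([C@@H]2O[C@H](CO)[C@@H](O)[C@H]2O)c2ncnc(OC)c12` to compound 4 `C#Cc1cn([C@@H]2O[C@H](CO)[C@@H](O)[C@H]2O)c2ncnc(NC)c12`. In an ADME assay on BJ cells (Homo sapiens), read by MTT assay, with a stated time of 72 h (on this read-out higher numbers stand for weaker inhibition and lower numbers for stronger inhibition), compound 1 gives 98400 nM. Compound 3 `CNc1ncnc2c1c(-c1cc3ccccc3o1)cn2[C@@H]1O[C@H](CO)[C@@H](O)[C@H]1O` gives 75600 nM, which is within the scatter of the value for compound 1. Compound 2 `CNc1ncnc2c1c(-c1ccsc1)cn2[C@@H]1O[C@H](CO)[C@@H](O)[C@H]1O` reports > 100000 nM, which is a limit of the assay and not a number.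

The change is methylamino in place of methoxy on an aromatic carbon. Among the compounds with values here, no measured step covers this exchange directly. Within the data shown here, the only step available, an at least 1.3-fold lower number from compound 2 to compound 3 (0.12 log units; that floor lies within the scatter), is 1-benzofuran-2-yl in place of thiophen-3-yl on an aromatic carbon, with methylamino present on both sides, so it bears on the exchange only indirectly.

Only a small change is expected in this assay because methylamino-bearing compound 3 gives 75600 nM. The expected change is a 1.2-fold lower number from compound 1 to compound 4 (0.09 log units; within the scatter), and a report of only a limit would be no surprise. Compound 4 is estimated at 80000 nM, with an expected range from 30000 nM to 100000 nM.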

Compound 4, half-maximal inhibitory concentration: 86000 nM
Estimate against measurement, compound 4: 1.1-fold (0.03 log units) below; the range from low to high includes it.
By their numbers in this assay, from the lowest: compounds 3, 4 and 1 (each within the scatter of the next). At a limit, above all of these: compound 2.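

Within the data shown here, with ethynyl on both sides, the exchange in this assay gives a 1.1-fold lower number from compound 1 to compound 4 (0.06 log units; within the scatter) and so provides the first direct reading of methylamino in place of methoxy at this position, next to the ring nitrogen. With methylamino on both sides, changing the other substituent gives a 1.1-fold higher number from compound 3 to compound 4 (0.06 log units; within the scatter) and an at least 1.1-fold lower number from compound 2 to compound 4 (0.06 log units; that floor lies within the scatter) and so no step among these compounds clears the scatter. Compound 2 remains a limit of the assay and not a number: the limit of > 100000 nM in this assay, at which 1 of the 4 values shown sits.

On these data alone, whether an unsubstituted amine, a dimethylamino group or a longer alkoxy chain at this position would give a number clearly apart from these remains open. Also open, as far as these compounds go, is whether methoxy and methylamino would still read alike with 1-benzofuran-2-yl or thiophen-3-yl in place of ethynyl.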